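A nitro for a chloro on the urea aryl

The compounds below may be only part of what the source reports. "The series", "measured", "known", "first", "only" and "open" are said of these compounds alone.

Compound 3 `O=C(Nc1cccc(Cl)c1)Nc1cccc(CNc2ncnc3ccccc23)c1` is the only one of the three measured compounds with a number in a functional assay on MGC-803 cells (Homo sapiens) for antiproliferative activity, read by MTT assay; a lower number here means a stronger inhibitor, a higher number a weaker inhibitor: compound 3 gives 19200 nM. For compound 1 `Cc1ccccc1NC(=O)Nc1cccc(CNc2ncnc3ccccc23)c1` the result in this assay is a limit, > 50000 nM. For compound 2 `O=C(Nc1cccc(CNc2ncnc3ccccc23)c1)Nc1ccccc1Cl` the result is likewise a limit, > 50000 nM. Both limits sit at the limit of > 50000 nM in this assay, at which 2 of the 3 values shown sit. The measured steps were an at least 2.6-fold lower number from compound 1 to compound 3 (0.41 log units; beyond the scatter) and an at least 2.6-fold lower number from compound 2 to compound 3 (0.41 log units; beyond the scatter), while the step that the two limits leave unreadable from compound 1 to compound 2. Compound 4 `O=C(Nc1ccc([N+](=O)[O-])cc1)Nc1cccc(CNc2ncnc3ccccc23)c1` differs from compound 3 by 4-nitrophenyl in place of 3-chlorophenyl on an amide-type nitrogen. Among the measured compounds shown here, no measured step tests this change, so no movement beyond the scatter is expected, with a real chance that compound 4 again returns only a limit. Compound 4 is therefore expected to give about 25000 nM, between 8000 nM and 80000 nM. That amounts to an expected step of a 1.3-fold higher number from compound 3 to compound 4 (0.11 log units; within the scatter).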

Compound 4, half-maximal inhibitory concentration: 9420 nM
The estimate for compound 4 lay 2.7-fold (0.42 log units) above the measured number, and the stated range covers the measured number.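

Among the compounds shown here, the change to 4-nitrophenyl on the amide-type nitrogen gives in this assay the first step at this position read between two numbers, with a 2.0-fold lower number from compound 3 to compound 4 (0.31 log units; beyond the scatter) and so no limit at either end. Both an at least 5.3-fold lower number from compound 2 to compound 4 (0.72 log units; beyond the scatter) and an at least 5.3-fold lower number from compound 1 to compound 4 (0.72 log units; beyond the scatter) start from a limit and are therefore bounds only: the limit of > 50000 nM in this assay, at which 2 of the 4 values shown sit. The compounds shown leave open whether 4-chlorophenyl or 3-nitrophenyl would match 4-nitrophenyl. They also leave open how an aminophenyl or a carboxyphenyl group would read on this nitrogen.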